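This account rests on a few compounds, and the source may have more. Where it says the series, first, only, none or still open, it means among the compounds named here.

The account begins with two compounds that share one core and differ only in the aromatic group attached to the carbon with a double bond to nitrogen. Compound 1 `Nc1nc(N/N=C/c2ccc3ncccc3c2)nc2c1ncn2[C@@H]1O[C@H](CO)[C@@H](O)[C@H]1O` carries quinolin-6-yl there; in an assay on CHO-K1 cells for displacement of a labelled ligand from adenosine receptor A1 (Homo sapiens), read by scintillation counting, with a stated time of 60 min (a higher number here means a weaker inhibitor, a lower number a stronger inhibitor), compound 1 gives 9.8 nM. Compound 2 `CCCOc1ccc(/C=N/Nc2nc(N)c3ncn([C@@H]4O[C@H](CO)[C@@H](O)[C@H]4O)c3n2)cc1` carries 4-propoxyphenyl in the same place. In this assay compound 2 reaches only a limit, > 10000 nM. The single step between the two measured compounds is an at least 1000-fold higher number from compound 1 to compound 2 (3.00 log units; beyond the scatter), and its size rests on (the limit of > 10000 nM in this assay, at which 1 of the 2 values shown sits), so compound 2 stands at the weak end of the numbers shown, with no exact value of its own.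

Compound 3 `Nc1nc(N/N=C/c2ccc(Cl)c(C(F)(F)F)c2)nc2c1ncn2[C@@H]1O[C@H](CO)[C@@H](O)[C@H]1O` is not yet measured. It differs from compound 2 by 4-chloro-3-(trifluoromethyl)phenyl in place of 4-propoxyphenyl on a carbon with a double bond to nitrogen. Among the measured compounds shown here, only the step from compound 1 to compound 2 bears on this change, and it concerns a different replacement, so it sets little more than the starting point. The expected step in this assay is therefore uncertain in direction, and the estimate for compound 3 is 5000 nM, between 500 nM and 30000 nM, which would mean an at least 2.0-fold lower number from compound 2 to compound 3 (0.30 log units; that floor lies within the scatter) if compound 2 sits near its limit.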

Compound 3, inhibition constant: > 10000 nM
Compound 3: a limit, no number; the forecaster's own chance of this, stated with the estimate: 50%; middle value at least 2.0-fold (0.30 log units) from the limit.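

In this assay, replacing quinolin-6-yl with 4-chloro-3-(trifluoromethyl)phenyl on a carbon with a double bond to nitrogen gives an at least 1000-fold higher number from compound 1 to compound 3 (3.00 log units; beyond the scatter). The large rise seen with 4-propoxyphenyl is therefore not specific to that one group: a second substituted phenyl, which shares no substituent with it and has no hydrogen-bond acceptor, also ends at a limit rather than a number, and the size of both steps from compound 1 rests on that limit: the limit of > 10000 nM in this assay, at which 2 of the 3 values shown sit. The step between compound 2 and compound 3 cannot be read, since both compounds stand at a limit, so these two groups cannot be ranked against each other.

The compounds shown leave open how far the value at this place depends on quinolin-6-yl itself, as only one group here gives a number. A naphthalen-2-yl or a pyridin-3-yl group in the same place, or an unsubstituted phenyl, would show whether any other aromatic group returns a measurable value.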